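The source may report more compounds than this note shows. Statements on the series, on what has been measured and on what is new or still open speak of the compounds shown alone.

Measured compounds:
`O=c1cc(CSC(=S)N2CCCCC2)oc2cc(Cl)ccc12` — compound 1, in a functional assay on SW480 cells (Homo sapiens) for antiproliferative activity, read by MTT assay, with a stated time of 72 h (on this read-out higher numbers stand for weaker inhibition and lower numbers for stronger inhibition), compound 1 gives 2500 nM.
`CCN(CC)C(=S)SCc1cc(=O)c2ccc(Cl)cc2o1` — compound 2, in this assay compound 2 gives > 25000 nM.

The value of compound 2 is a limit of this assay and not a number (the limit of > 25000 nM in this assay, at which 1 of the 2 values shown sits). The only measured step here is an at least 10-fold higher number from compound 1 to compound 2 (1.00 log units; beyond the scatter), which puts compound 2 at the weak end of what is shown. Compound 3 `O=c1cc(CSC(=S)N2CCOCC2)oc2cc(Cl)ccc12` has not been measured; it differs from compound 2 in morpholin-4-yl in place of diethylamino on a thiocarbonyl carbon. Within the data shown here, the morpholin-4-yl of compound 3 is again a six-membered non-aromatic ring on the thiocarbonyl carbon, as the piperidin-1-yl of compound 1 was, so the step of an at least 10-fold higher number from compound 1 to compound 2 (1.00 log units; beyond the scatter) is the one measured step that bears on this change, and a partial return toward lower numbers is expected. Compound 3 is therefore expected to show an at least 4.1-fold lower number from compound 2 to compound 3 (0.61 log units; beyond the scatter). For compound 3 the estimate in this assay is 6000 nM, between 1500 nM and 25000 nM.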

Compound 3, half-maximal inhibitory concentration: > 25000 nM
Compound 3 gave a limit, no number (the forecaster's own chance of this, stated with the estimate: 35%); at least 4.1-fold (0.61 log units) between middle value and limit.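

In this assay compound 3 gives > 25000 nM, which is a limit of the assay and not a number. Morpholin-4-yl in place of piperidin-1-yl on the thiocarbonyl carbon gives an at least 10-fold higher number from compound 1 to compound 3 (1.00 log units; beyond the scatter), so a six-membered non-aromatic ring at this place does not by itself hold the level of compound 1. The step between diethylamino and morpholin-4-yl cannot be read, since compound 2 and compound 3 share one limit: the limit of > 25000 nM in this assay, at which 2 of the 3 values shown sit.

The compounds shown leave open how far compound 2 and compound 3 lie beyond that limit. They also leave open whether another amine on the thiocarbonyl carbon, such as a pyrrolidine or a piperazine, would match compound 1 or give a lower number.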